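The source may report more compounds than this note shows. Statements on the series, on what has been measured and on what is new or still open speak of the compounds shown alone.

In a functional assay on MCF7 cells (Homo sapiens) for inhibition, read by MTT assay (on this read-out lower numbers stand for stronger inhibition and higher numbers for weaker inhibition), compound 1 `COc1cc2ncnc(Nc3ccc(NC(=O)c4ccccc4OC)cc3)c2cc1OC` gives > 100000 nM, which is a limit of the assay and not a number. Compound 2 `COc1cc2ncnc(Nc3ccc(NC(=O)c4ccccc4F)cc3)c2cc1OC` gives 11000 nM. Among the measured compounds shown here, compound 3 `COc1cc2ncnc(Nc3ccc(NC(=O)c4ccc(Br)cc4)cc3)c2cc1OC` gives 43000 nM, the higher of the two actual numbers so far.

Compound 4 `COc1cc2ncnc(Nc3ccc(NC(=O)c4cccc(C(F)(F)F)c4)cc3)c2cc1OC` keeps the shared core and the amide of compound 3 and changes only the aryl group: 3-(trifluoromethyl)phenyl in place of 4-bromophenyl on a carbonyl carbon. In words, this is 3-(trifluoromethyl)phenyl in place of 4-bromophenyl on a carbonyl carbon.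

The closest measured precedent is the other exchange of a whole aryl group with two real numbers, a 3.9-fold higher number from compound 2 to compound 3 (0.59 log units; beyond the scatter), which is modest. The steps involving compound 1, an at least 9.0-fold lower number from compound 1 to compound 2 (0.95 log units; beyond the scatter) and an at least 2.3-fold lower number from compound 1 to compound 3 (0.36 log units; beyond the scatter), rest on its limit and give only minimum sizes. None of these steps introduces 3-(trifluoromethyl)phenyl, so they suggest a size but no firm direction.

A small step is therefore expected in this assay, at most modest and slightly towards a lower number. The expected step is a 1.4-fold lower number from compound 3 to compound 4 (0.16 log units; within the scatter). Compound 4 is estimated at 30000 nM, with an expected range of 9000 nM to 100000 nM.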

Compound 4, half-maximal inhibitory concentration: > 100000 nM
Compound 4: a limit, no number; the forecaster's own chance of this, stated with the estimate: 15%; middle value at least 3.3-fold (0.52 log units) away from the limit.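

In this assay, replacing the aryl group on the carbonyl carbon with 3-(trifluoromethyl)phenyl gives an at least 2.3-fold higher number from compound 3 to compound 4 (0.36 log units; beyond the scatter) and an at least 9.0-fold higher number from compound 2 to compound 4 (0.95 log units; beyond the scatter), both minimum sizes, so this position does not tolerate every halogen-bearing aryl group equally. Compound 4 gives > 100000 nM, a limit and not a number, and the step from compound 1 cannot be read. Among the aryl groups shown, 3-(trifluoromethyl)phenyl now joins 2-methoxyphenyl at the end of the measurable range, leaving only compound 2 and compound 3 with real numbers: the limit of > 100000 nM in this assay, at which 2 of the 4 values shown sit.

No order can be given between compound 1 and compound 4. From the compounds shown here alone, compound 4 differs from compound 3 in both the substituent and its place on the aryl ring, so these two changes remain unseparated, and the effect of an amine or a carboxylic acid on this aryl group remains open.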